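Methyl on the Cyclohexyl Ring: Expected Solubility of Compound 3

The source may report more compounds than this note shows. Statements on the series, on what has been measured and on what is new or still open speak of the compounds shown alone.

Measured compounds:
compound 1, `CC(=O)Nc1cc(C)c(CCS(=O)(=O)N2CCC3(CC2)N=C(C2CCCCC2)NC3=O)c(C)c1`: 38 ug/mL
compound 2, `Cc1cc(N(C)C(N)=O)cc(C)c1CCS(=O)(=O)N1CCC2(CC1)N=C(C1CCCCC1)NC2=O`: 450 ug/mL

Within the data shown here, in a physicochemical assay for solubility, read by HPLC, in simulated intestinal fluid, tested at 1 mM (a lower number here means a less soluble compound, a higher number a more soluble compound), compound 2 gives 450 ug/mL, the higher of the two numbers measured so far; compound 1 gives 38 ug/mL. Among the measured compounds shown here, the only measured step, a 12-fold higher number from compound 1 to compound 2 (1.07 log units; beyond the scatter), concerns the aromatic substituent and not the saturated ring. Compound 3, `Cc1cc(N(C)C(N)=O)cc(C)c1CCS(=O)(=O)N1CCC2(CC1)N=C([C@H]1CC[C@H](C)CC1)NC2=O`, differs from compound 2 by methyl in place of hydrogen on a saturated ring carbon. For the measured compounds named here, no measured step touches that ring, so the data give no direct precedent for this change. One added carbon on a saturated ring usually lowers a solubility read-out only modestly, and compound 2 already sits near the top of this set. Compound 3 is therefore expected to give a somewhat lower number, a 2.3-fold lower number from compound 2 to compound 3 (0.35 log units; beyond the scatter), a step of moderate size at most. The estimate for compound 3 in this assay is 200 ug/mL, with a likely range from 80 ug/mL to 450 ug/mL.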

Compound 3, solubility: 250 ug/mL
For compound 3 the middle estimate is 1.3-fold (0.10 log units) below the measured one; measured number inside the range.
By their numbers in this assay, from the lowest: compound 1; then compounds 3 and 2 (each within the scatter of the next).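

This is the first step shown on the saturated ring, the change from cyclohexyl to 4-methylcyclohexyl, and in this assay it reads a 1.8-fold lower number from compound 2 to compound 3 (0.26 log units; within the scatter). At this ring carbon, three ring bonds from the ring atom that bears a large group, methyl in place of hydrogen thus stays within the scatter, whereas the aromatic change, a 12-fold higher number from compound 1 to compound 2 (1.07 log units; beyond the scatter), lies beyond it. Nothing among the data shown accounts for this result.

As far as these compounds go, whether an amine, a carboxylic acid or a longer chain such as ethyl at the same ring carbon would give a step beyond the scatter remains open. Also open, from the compounds shown here alone, is whether methyl in place of hydrogen gives a similar step when acetamido, as in compound 1, stands on the aromatic carbon.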